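Changing the group on the aromatic carbon of compound 3

The source may hold more compounds than are shown below. What is called first, only, known or untested is meant among the compounds shown, and "the series" means these compounds.

compound 1 `CC/N=C(/N)Nc1nc(-c2ccc(OC)cc2)c(-c2ccc(OC)cc2)s1`: > 100 nM (a limit, not a number)
compound 2 `COc1ccc(-c2nc(/N=C(\N)N(C)C)sc2-c2ccc(OC)cc2)cc1`: 37 nM
compound 3 `C/N=C(/NC)Nc1nc(-c2ccc(OC)cc2)c(-c2ccc(OC)cc2)s1`: 970 nM

In a functional assay with Oryctolagus cuniculus as the target (on this read-out lower numbers stand for stronger inhibition and higher numbers for weaker inhibition), compound 3 gives 970 nM, the higher of the two actual numbers. Compound 4 (`COc1ccc(-c2nc(/N=C(\N)n3ccnc3)sc2-c2ccc(OC)cc2)cc1`) differs from it as follows: a group of 8 heavy atoms (4 carbon, 4 nitrogen; one five-membered aromatic ring with 2 hetero atoms) in place of a group of 6 heavy atoms (3 carbon, 3 nitrogen; no ring), on an aromatic carbon. Two measured steps involve a swap on this same aromatic carbon. The step of a 26-fold higher number from compound 2 to compound 3 (1.42 log units; beyond the scatter) is large, and the step of an at least 2.7-fold lower number from compound 1 to compound 2 (0.43 log units; beyond the scatter) is at least modest. Among these compounds, then, this group can move the number strongly, and compound 2 reaches 37 nM. Among the measured compounds shown here, no measured compound carries a ring in this group, so the size of the change remains uncertain. A lower number is expected, as a 6.5-fold lower number from compound 3 to compound 4 (0.81 log units; beyond the scatter). For compound 4 the estimated value is 150 nM, with an expected range of 30 nM to 700 nM.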

Compound 4, half-maximal inhibitory concentration: > 100 nM
Compound 4: a limit, no number; the forecaster's own chance of this, stated with the estimate: 15%; the middle value is on the limit's open side.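

Compound 4 gives a limit, not a number: the limit of > 100 nM in this assay, at which 2 of the 4 values shown sit. Even so, 1H-imidazol-1-yl in place of dimethylamino gives an at least 2.7-fold higher number from compound 2 to compound 4 (0.43 log units; beyond the scatter), so this aromatic ring does not keep the low number that the dimethylamino group gives in this pair. The steps to compound 4 from compound 1 and from compound 3 cannot be read. As far as these compounds go, the true value of compound 4 stays open. From the compounds shown here alone, it is also open whether pyrrolidine, morpholine or diethylamino in this group would behave more like dimethylamino or like 1H-imidazol-1-yl.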